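The source may report more compounds than this note shows. Statements on the series, on what has been measured and on what is new or still open speak of the compounds shown alone.

The measured compounds:
compound 1, `COc1cc(C2=NN(C(C)=O)C(c3ccc(F)c(F)c3)O2)cc(OC)c1OC`, with 35.5% in a functional assay on PC-3 cells (Homo sapiens) for antiproliferative activity, read by MTT assay, tested at 1 uM; a higher number here means a stronger effect of the compound at the concentration tested, a lower number a weaker effect
compound 2, `COc1cc(C(=O)N/N=C/c2cccc(C(F)(F)F)c2)cc(OC)c1OC`, with 51%
compound 3, `COc1cc(C(=O)N/N=C/c2ccc(Cl)c([N+](=O)[O-])c2)cc(OC)c1OC`, with 32.1%

Among the compounds with values here, of these three numbers, the one for compound 1 is the second highest. Its nearest neighbour is compound 3, whose number lies lower by an amount within the usual scatter, so the two cannot be told apart with confidence. The furthest is compound 2, whose number lies higher by an amount beyond the scatter, so compound 2 gives the clearer effect of the three.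

The unmeasured compound 4, `COc1cc(C2=NN(C(C)=O)C(c3ccc(Cl)c(Cl)c3)O2)cc(OC)c1OC`, shares the core of compound 1 and differs from it in a single place: 3,4-dichlorophenyl in place of 3,4-difluorophenyl on a saturated ring carbon. Within the data shown here, no pair of measured compounds shows this exchange, so there is no measured step to lean on, and the expectation rests on compound 1 alone. Swapping one pair of halogen atoms for another on the same ring is a small change, and the step in this assay is expected to be small, most likely within the scatter, with at best a slight lean upward. Compound 4 is therefore estimated at 40%, within a range from 25% to 55%. The expected step is a number 4.5 percentage points higher from compound 1 to compound 4 (within the scatter).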

Compound 4, a percentage reported as inhibition, at one concentration (the size of the read-out at that concentration, not a potency): 28.1%
The estimate for compound 4 lay 11.9 percentage points above the measured number; measured number inside the range.
By their numbers in this assay, from the lowest: compounds 4, 3 and 1 (each within the scatter of the next); then compound 2.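

In this assay, the exchange of 3,4-difluorophenyl for 3,4-dichlorophenyl on the saturated ring carbon gives a number 7.4 percentage points lower from compound 1 to compound 4 (within the scatter). Within the data shown here, this is the first measured step at this position, and it shows that the read-out does not separate these two halogen pairs on the shared core: fluorine and chlorine on this ring cannot be told apart with confidence. No measurement here offers an explanation for the size of this step.

On these data alone, one exchange between two closely related halogen pairs, read at a single concentration, does not show how much this position matters, so it remains unknown whether a phenyl ring carrying a dimethylamino group or a carboxylic acid, or a ring with only one chlorine, would move the number beyond the scatter. Also open, as far as these compounds go, is how the acetyl group on the ring atom close to this position contributes, for example whether a propionyl group there would change the read-out, and whether the dichlorophenyl and difluorophenyl rings would still match once that group is altered.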